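Swapping nitro for trifluoromethyl across two shared-core series

This account rests on a few compounds, and the source may have more. Where it says the series, first, only, none or still open, it means among the compounds named here.

Measured compounds:
compound 1 `CC(c1ccc(-c2ccccc2)c(F)c1)c1nnc2n1N=C(c1ccc(C(F)(F)F)cc1)CS2`: 6100 nM
compound 2 `CC(C)Cc1ccc(C(C)c2nnc3n2N=C(c2ccc([N+](=O)[O-])cc2)CS3)cc1`: "not active" (no number reported)
compound 3 `CC(c1ccc(-c2ccccc2)c(F)c1)c1nnc2n1N=C(c1ccc([N+](=O)[O-])cc1)CS2`: 7100 nM

Compounds 1 and 3 share one core and differ in a single place; compound 2 carries a different core, and the difference between the two cores is not broken down here. In a functional assay on HCT-116 cells (Homo sapiens) for inhibition, read by sulforhodamine B assay, with a stated time of 72 h (a lower number here means a stronger inhibitor, a higher number a weaker inhibitor), compound 3 gives 7100 nM. In this assay compound 1 gives 6100 nM. The change between them is trifluoromethyl in place of nitro on an aromatic carbon, and it made a 1.2-fold lower number from compound 3 to compound 1 (0.07 log units; within the scatter), so the two values cannot be told apart.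

Compound 2 is reported in this assay as "not active" (no number reported), with no number behind it.

Compound 4 `CC(C)Cc1ccc(C(C)c2nnc3n2N=C(c2ccc(C(F)(F)F)cc2)CS3)cc1` is not yet measured. It arises from compound 2 by trifluoromethyl in place of nitro on an aromatic carbon, the same change as from compound 3 to compound 1, made at the same place. That earlier step left the value essentially unchanged, so the step from compound 2 to compound 4 in this assay is expected to be small as well, resting only on a 1.2-fold lower number from compound 3 to compound 1 (0.07 log units; within the scatter). Compound 4 is therefore expected to remain weak, around 25000 nM, somewhere between 7000 nM and 90000 nM, with a fair chance that no number is reported at all.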

Compound 4, half-maximal inhibitory concentration: 6500 nM
Compound 4: the middle estimate sits 3.8-fold (0.59 log units) above what was measured; measured number outside the range, below it.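

Going by these compounds alone, compound 2 is reported only as "not active" in this assay, while compound 4 gives 6500 nM, so no step from compound 2 to compound 4 can be read. Nothing available here explains this result. The compounds shown leave open how much swapping nitro for trifluoromethyl changes the value on the core of compound 2.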